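A few compounds are considered here, and "the series" means these few. Any claim that something is new, unique, unknown or untested is made for them only; others in the source may bear on it.

Compound 1 `CC/N=C(/NC#N)NCCCCCn1nc(-c2ccccc2)ccc1=O`: 60.3 mg/kg
Compound 2 `C/N=C(\NC#N)NCCCCn1nc(-c2ccccc2)ccc1=O`: 38.5 mg/kg
Compound 3 `NC(=O)SCCCCCN1NC=CC=C1c1ccccc1`: 18.3 mg/kg

Of the compounds shown here, three have been tested in a functional assay on the whole organism with Rattus norvegicus as the target; on this read-out higher numbers stand for an effect only at larger amounts of compound and lower numbers for an effect already at smaller amounts. Compound 1 gives 60.3 mg/kg in this assay, compound 2 gives 38.5 mg/kg, and compound 3 gives 18.3 mg/kg. Compound 2 stands second highest of the three numbers. Its nearest neighbour is compound 1, whose number lies within the usual scatter of that of compound 2, so the two cannot be told apart on this read-out. Compound 3 lies furthest away from compound 2, with a lower number that is beyond the scatter.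

Compound 4 `CC/N=C(/NC#N)NCCCn1nc(-c2ccccc2)ccc1=O` has not yet been measured. It has the same atoms as compound 2, joined differently: a group of 8 heavy atoms (4 carbon, 4 nitrogen; no ring) in place of a group of 8 heavy atoms (4 carbon, 4 nitrogen; no ring), on a saturated chain carbon, three bonds along the chain from an aromatic nitrogen. For the measured compounds named here, no pair of measured compounds differs in this one place, so no measured step shows what such a rearrangement does in this assay. Compound 1 and compound 2 differ from each other in more than one place, and their values lie within the scatter of each other, which gives no direction either. With nothing pointing one way, the step of a 1.0-fold higher number from compound 2 to compound 4 (0.02 log units; within the scatter) is expected to stay within the scatter, in either direction. Compound 4 is estimated at 40 mg/kg, with a range from 15 mg/kg to 110 mg/kg.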

Compound 4, dose for half-maximal effect: 88.5 mg/kg
Compound 4: middle estimate off by 2.2-fold (0.34 log units), on the low side; low and high end bracket the measured number.
By their numbers in this assay, from the lowest: compound 3; then compounds 2, 1 and 4 (each within the scatter of the next, the first and the last beyond it).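

In this assay, for the compounds shown here, the rearrangement gives a 2.3-fold higher number from compound 2 to compound 4 (0.36 log units; beyond the scatter) as the first measured change confined to one place, and it moves towards an effect only at larger amounts of compound. The group that leaves and the group that enters have the same heavy atoms, the same double and triple bonds, the same hydrogen-bond donors and acceptors and no net charge, so this place on the saturated chain carbon responds to how the atoms are joined and not only to which atoms are present. No measurement at hand speaks to why the number moves in this direction.

This modest step describes one rearrangement only and gives no rule for other groups at this place. From the compounds shown here alone, whether a simple amine, a carboxylic acid or an ether on that saturated chain carbon, three bonds along the chain from an aromatic nitrogen, would keep the number close to that of compound 2 or move it further remains open.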